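The compounds below may be only part of what the source reports. "The series", "measured", "known", "first", "only" and "open" are said of these compounds alone.

Measured compounds in this series:

Compound 1, `Cc1cccc(-n2nncc2CN2C(=O)C3(C(C#N)=C(N)Oc4c3c3nc5ccccc5nc3c3ccccc43)c3ccccc32)c1`: in an ADME assay on L02 cells (Homo sapiens) for antiproliferative activity, read by MTT assay, with a stated time of 48 h (on this read-out higher numbers stand for weaker inhibition and lower numbers for stronger inhibition), compound 1 reaches only the assay limit, > 50000 nM.
Compound 2, `N#CC1=C(N)Oc2c(c3nc4ccccc4nc3c3ccccc23)C12C(=O)N(Cc1cnnn1-c1cccc(Cl)c1)c1ccccc12`: in this assay compound 2 gives 35200 nM.
Compound 3, `N#CC1=C(N)Oc2c(N)cc3nc4ccccc4nc3c2C12C(=O)N(Cc1cnnn1-c1ccccc1Cl)c1ccccc12`: in this assay compound 3 reaches only the assay limit, > 50000 nM.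

Compound 3 thus stands at the limit of > 50000 nM in this assay, at which 2 of the 3 values shown sit, and no number is known for it. Going by the values given here, the single numbered value in the set, that of compound 2, does not lie far from that limit. Among the compounds with values here, the only measured step with one change is an at least 1.4-fold lower number from compound 1 to compound 2 (0.15 log units; that floor lies within the scatter); it lies within the scatter and alters a substituent on the phenyl attached to the aromatic nitrogen of the five-membered aromatic ring with 3 nitrogen.

Compound 4, `COc1ccc(OC)c(-n2nncc2CN2C(=O)C3(C(C#N)=C(N)Oc4c(N)cc5nc6ccccc6nc5c43)c3ccccc32)c1`, differs from compound 3 by 2,5-dimethoxyphenyl in place of 2-chlorophenyl on an aromatic nitrogen. Within the data shown here, this change sits at the same phenyl that the one measured step alters, and that step stayed within the scatter. No step beyond the scatter is therefore expected in this assay, in either direction. Compound 4 is expected to give about 50000 nM, within a range from 20000 nM to 120000 nM, most likely reported again as a limit. The step this estimate means, a number no higher from compound 3 to compound 4 (the limit leaves the size open), is expected to stay within the scatter.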

Compound 4, half-maximal inhibitory concentration: > 50000 nM
Compound 4 gave a limit, no number; the forecaster's own chance of this, stated with the estimate: 65%; the middle value lies on the limit itself.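

No step can be read from compound 3 to compound 4, as both results in this assay are limits and not numbers: the limit of > 50000 nM in this assay, at which 3 of the 4 values shown sit.

The compounds shown leave open whether 2,5-dimethoxyphenyl in place of 2-chlorophenyl shifts the read-out at all, and where either compound's actual number lies.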